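The source may report more compounds than this note shows. Statements on the series, on what has been measured and on what is new or still open speak of the compounds shown alone.

Measured compounds in an assay on HeLa cells for binding affinity to Vasopressin V2 receptor (Homo sapiens); a higher number here means a weaker inhibitor, a lower number a stronger inhibitor:
- compound 1 `CCN(CC)c1ccc(C(=O)N2CCCCc3ccccc32)c(Cl)c1` gives 19 nM
- compound 2 `CCCCNc1ccc(C(=O)N2CCCCc3ccccc32)c(Cl)c1` gives 22 nM

Compound 2 holds the highest of the two numbers in this assay, yet its nearest neighbour, compound 1, sits within the scatter of it, so no order between the two can be claimed. The next compound, compound 3 `O=C(c1ccc(N2CCCCC2)cc1Cl)N1CCCCc2ccccc21`, is not yet measured. It differs from compound 2 in one place: piperidin-1-yl in place of butylamino on an aromatic carbon.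

For the measured compounds named here, one measured step bears on this change. The exchange of the group on the same aromatic carbon, a 1.2-fold higher number from compound 1 to compound 2 (0.06 log units; within the scatter), left the number essentially unmoved. Compound 1 already carries a tertiary amine there, and compound 3 carries the ring-closed counterpart, so the move back to a tertiary amine is expected to cost or gain little beyond the scatter. For compound 3 the expected step is a 1.1-fold lower number from compound 2 to compound 3 (0.04 log units; within the scatter). Compound 3 is therefore estimated at 20 nM, with a range from 8 nM to 50 nM.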

Compound 3, half-maximal inhibitory concentration: 120 nM
Compound 3: the middle estimate sits 6.0-fold (0.78 log units) below what was measured, and the stated range ends below it.
By their numbers in this assay, from the lowest: compounds 1 and 2 (each within the scatter of the next); then compound 3.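

In this assay this aromatic carbon proves less tolerant than the first two compounds suggested: butylamino gives way to piperidin-1-yl with a 5.5-fold higher number from compound 2 to compound 3 (0.74 log units; beyond the scatter) and diethylamino gives way to it with a 6.3-fold higher number from compound 1 to compound 3 (0.80 log units; beyond the scatter) as the two steps. Compound 1 also has no amine hydrogen, so the loss of the hydrogen-bond donor does not on its own follow the rise; among these three compounds, only compound 3 carries the substituent closed into a ring. Nothing available here accounts for the rise.

Three compounds cannot show whether the rise belongs to ring closure in general or to piperidin-1-yl in particular. Pyrrolidin-1-yl or morpholin-4-yl on the same carbon would bear on that question, and the open-chain dipropylamino group would test how far the tolerance of open chains extends.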